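Weak inhibition expected on moving to a halogenated phenyl

The source may hold more compounds than are shown below. What is called first, only, known or untested is meant among the compounds shown, and "the series" means these compounds.

Measured in a functional assay on B16 cells (Mus musculus) for antiproliferative activity, with a stated time of 72 h; on this read-out higher numbers stand for weaker inhibition and lower numbers for stronger inhibition:
- Compound 1 `OC[C@H]1O[C@@H](n2cnc3c(NCc4ccccc4Br)ncnc32)[C@H](O)[C@@H]1O`: > 166000 nM
- Compound 2 `COc1ccc(CNc2ncnc3c2ncn3[C@@H]2O[C@H](CO)[C@@H](O)[C@H]2O)c(OC)c1`: "not determined" (no result reported)
- Compound 3 `COc1cc(CNc2ncnc3c2ncn3[C@@H]2O[C@H](CO)[C@@H](O)[C@H]2O)cc(OC)c1`: "not determined" (no result reported)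

Compound 3 has no number to stand on, and its entry reads "not determined" (no result reported), as does that of compound 2. The only other entry is a limit, not a number: the limit of > 166000 nM in this assay, at which 1 of the 3 values shown sits, from compound 1.

Compound 4 `OC[C@H]1O[C@@H](n2cnc3c(NCc4ccc(F)c(Cl)c4)ncnc32)[C@H](O)[C@@H]1O` is still unmeasured. The change 3-chloro-4-fluorophenyl in place of 3,5-dimethoxyphenyl on a saturated chain carbon bound to a nitrogen on an aromatic ring places 3-chloro-4-fluorophenyl in place of 3,5-dimethoxyphenyl on a saturated chain carbon bound to a nitrogen on an aromatic ring.

With no number for compound 3, the size of this step in this assay cannot be stated, and no direction is expected from it. Compound 1 also carries halogen on its phenyl ring, and its > 166000 nM is a limit. Weak inhibition is therefore expected for compound 4, resting only on that single entry for compound 1 at > 166000 nM. In this assay the expected value for compound 4 is 120000 nM, with an estimated range from 30000 nM to 300000 nM.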

Compound 4, half-maximal inhibitory concentration: 167000 nM
Estimate against measurement, compound 4: 1.4-fold (0.14 log units) below; the measured number falls inside the stated range.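

No step can be read from compound 1 to compound 4 in this assay, because the entry for compound 1 is a limit and not a number: the limit of > 166000 nM in this assay, at which 1 of the 4 values shown sits.

The compounds shown leave open whether any change on the phenyl ring shifts inhibition in this assay.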